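Cyclopentyl in place of isopropyl on an aminoquinoline-type core

This account rests on a few compounds, and the source may have more. Where it says the series, first, only, none or still open, it means among the compounds named here.

Compound 1, `CCCc1cc(N)c2cc(NC(=O)/C=C/c3ccc(Cl)cc3Cl)ccc2n1`, gives 904 nM.
Compound 2, `CC(C)c1cc(N)c2cc(NC(=O)/C=C/c3ccc(C(F)(F)F)cc3)ccc2n1`, gives 160 nM.
Compound 3, `CCCc1cc(N)c2cc(NC(=O)C3CCC(c4ccc(Cl)cc4)CC3)ccc2n1`, gives 370 nM.

These three values come from a functional assay on HEK293 cells for activation of melanin-concentrating hormone receptor 1 (Homo sapiens), read by inositol phosphate accumulation; on this read-out higher numbers stand for an effect only at larger amounts of compound and lower numbers for an effect already at smaller amounts. Among them compound 2 stands lowest, so it acts at the smallest amount of the three; compound 3 comes nearest to it and compound 1 lies furthest away, and both of those gaps are beyond the usual scatter of repeated measurements.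

The next compound, compound 4, `Nc1cc(C2CCCC2)nc2ccc(NC(=O)/C=C/c3ccc(C(F)(F)F)cc3)cc12`, differs from compound 2 in one place only: cyclopentyl in place of isopropyl on an aromatic carbon. The rest of the molecule, including the amide-linked trifluoromethyl-bearing side chain, is unchanged.

Within the data shown here, no measured pair in this set shows what such an exchange does, so the expected step in this assay can only be a guess of no change beyond the scatter, with a small drift in either direction remaining possible. Compound 4 is therefore estimated at 160 nM, within a range from 60 nM to 450 nM, which means an expected step of no change at the digits printed from compound 2 to compound 4 (within the scatter).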

Compound 4, half-maximal effective concentration: 68 nM
The estimate for compound 4 lay 2.4-fold (0.37 log units) above the measured number, within the range that was stated.
By their numbers in this assay, from the lowest: compound 4; then compound 2; then compound 3; then compound 1.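

In this assay, cyclopentyl in place of isopropyl on the aromatic carbon next to the ring nitrogen gives a 2.4-fold lower number from compound 2 to compound 4 (0.37 log units; beyond the scatter). Among these compounds, this is the only pair here that differs in one place, and it shows that this position tolerates a group of five carbons in a ring where isopropyl has three carbons and no ring, with the effect now appearing at a smaller amount of compound. No measurement is available to explain this step.

One pair cannot separate the effect of the added carbons from that of the ring itself, and it cannot show whether the step would hold with a different amide side chain. On these data alone, how a cyclohexyl, a phenyl or a morpholine at this position would compare also remains open.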